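Methyl in Place of Hydrogen on Two Related Cores

This account rests on a few compounds, and the source may have more. Where it says the series, first, only, none or still open, it means among the compounds named here.

Compound 1 `COC(=O)[C@@]1(C)CCC=C2[C@@H]1CC[C@@H](C)[C@]2(C)Cc1c[nH]c2c(Cl)cccc12` gives 24000 nM in a functional assay on T47D cells (Homo sapiens) for inhibition, read by sulforhodamine B assay, with a stated time of 48 h; a lower number here means a stronger inhibitor of growth, a higher number a weaker inhibitor of growth. Compound 2 `COC(=O)[C@@]1(C)CCC=C2[C@@H]1CC[C@@H](C)[C@]2(C)Cc1c(C)[nH]c2c(Cl)cccc12` differs from it by methyl in place of hydrogen on an aromatic carbon and gives 27000 nM; the step is a 1.1-fold higher number from compound 1 to compound 2 (0.05 log units; within the scatter). Compound 3 `COC(=O)[C@@]1(C)CC[C@@H]2C3=C1CC[C@@H](C)[C@]3(C)Cc1c2[nH]c2ccccc12` has a different core; the difference between the two cores is not broken down here. In this assay compound 3 gives 3400 nM, the lowest number of the three. Compound 4 `COC(=O)[C@@]1(C)CC[C@@H]2C3=C1CC[C@@H](C)[C@]3(C)Cc1c2[nH]c2ccc(C)cc12` differs from compound 3 by methyl in place of hydrogen on an aromatic carbon. This is the same kind of change as that from compound 1 to compound 2, but the place differs: there the methyl sat on a five-membered aromatic ring with 1 nitrogen, next to the ring nitrogen and next to the ring atom that bears a large group; here it sits on a six-membered aromatic ring of carbon only, meta to a fused ring and para to a fused ring. Because a 1.1-fold higher number from compound 1 to compound 2 (0.05 log units; within the scatter) lay within the scatter, a similarly small step a 1.1-fold higher number from compound 3 to compound 4 (0.05 log units; within the scatter) is expected for compound 4, so its value is estimated at 3800 nM, most likely between 1700 nM and 8500 nM.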

Compound 4, concentration for 50% growth inhibition: 16000 nM
Estimate against measurement, compound 4: 4.2-fold (0.62 log units) below; measured number above the stated range.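

On the core of compound 3, methyl in place of hydrogen gave a 4.7-fold higher number from compound 3 to compound 4 (0.67 log units; beyond the scatter) in this assay, so a step too small to read on one core did not stay that small on the other. The two steps differ by more than their scatter: the same change on two cores in this assay, a 1.1-fold higher number (0.05 log units; within the scatter) from compound 1 to compound 2 and a 4.7-fold higher number (0.67 log units; beyond the scatter) from compound 3 to compound 4, 4.2-fold (0.62 log units) apart, beyond the scatter of two such steps

This does not show that the core alone separates them, as the methyl stands on a five-membered aromatic ring with 1 nitrogen in compound 2 and on a six-membered aromatic ring of carbon only in compound 4, and each core offers a single pair. As far as these compounds go, it remains open whether methyl in one matching place on both cores would give steps of similar size. From the compounds shown here alone, it also remains open whether an ethyl or a methoxy group at the place used in compound 4 would shift the number in the same direction.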